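Second Chloro on the Amide-Linked Aryl Ring

The source may report more compounds than this note shows. Statements on the series, on what has been measured and on what is new or still open speak of the compounds shown alone.

Three compounds have been measured in a functional assay on HT-29 cells (Homo sapiens) for inhibition, read by MTT assay, with a stated time of 72 h; on this read-out higher numbers stand for weaker inhibition and lower numbers for stronger inhibition:

compound 1, `COc1cc2c(Oc3ccc(NC(=O)c4nn(-c5ccccc5)c(=O)cc4C)cc3F)ccnc2cc1OCCCN1CCN(C)CC1`: 270 nM
compound 2, `COc1cc2c(Oc3ccc(NC(=O)c4nn(-c5ccc(Cl)cc5)c(=O)cc4C)cc3F)ccnc2cc1OCCCN1CCCCC1`: 360 nM
compound 3, `COc1cc2c(Oc3ccc(NC(=O)c4nn(-c5ccc(Cl)cc5)c(=O)cc4C)cc3F)ccnc2cc1OCCCN1CCN(C)CC1`: 320 nM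

Compound 1 and compound 3 differ by chloro in place of hydrogen on an aromatic carbon, and this gave a 1.2-fold higher number from compound 1 to compound 3 (0.07 log units; within the scatter). The step of a 1.1-fold lower number from compound 2 to compound 3 (0.05 log units; within the scatter) is likewise small. How the cores of compound 2 and compound 1 differ is not broken down here.

Compound 4, `COc1cc2c(Oc3ccc(NC(=O)c4nn(-c5ccc(Cl)cc5Cl)c(=O)cc4C)cc3F)ccnc2cc1OCCCN1CCCCC1`, differs from compound 2 by chloro in place of hydrogen on an aromatic carbon. This is the same kind of change as from compound 1 to compound 3, though here the entering chloro sits ortho to a large group and meta to a chloro group rather than para to a large group. The expected step is a 1.1-fold higher number from compound 2 to compound 4 (0.05 log units; within the scatter), resting on the earlier step of a 1.2-fold higher number from compound 1 to compound 3 (0.07 log units; within the scatter) having stayed within the scatter. Compound 4 is therefore estimated at 400 nM, expected to fall between 160 nM and 1000 nM.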

Compound 4, half-maximal inhibitory concentration: 290 nM
Estimate against measurement, compound 4: 1.4-fold (0.14 log units) above; the measured number falls inside the stated range.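

In this assay, the added chloro gives a 1.2-fold lower number from compound 2 to compound 4 (0.09 log units; within the scatter). Set beside the same change on the other core, the two steps cannot be told apart: the same change on two cores in this assay, a 1.2-fold higher number (0.07 log units; within the scatter) from compound 1 to compound 3 and a 1.2-fold lower number (0.09 log units; within the scatter) from compound 2 to compound 4, 1.5-fold (0.17 log units) apart, within the scatter of two such steps

So in these two pairs, adding a chloro to this aromatic ring leaves the number essentially unchanged on both cores, but this does not show that it would do so on any other core, and the chloro enters at a different place in each pair, so the two steps do not test one position.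

Still open, on these data alone, is whether a trifluoromethyl or methoxy group on this ring would move the number beyond the scatter. Also open, as far as these compounds go, is whether the second chloro would behave the same way with 4-methylpiperazin-1-yl on the chain.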